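Adding an amino acid side chain to compound 2

The compounds below may be only part of what the source reports. "The series", "measured", "known", "first", "only" and "open" are said of these compounds alone.

In a functional assay on HeLa cells (Homo sapiens) for cytotoxicity, read by MTT assay, with a stated time of 72 h (on this read-out lower numbers stand for stronger inhibition and higher numbers for weaker inhibition), compound 2 `CC1=CCC[C@H]2[C@](C)(CC3=CC(=O)C=CC3=O)[C@@H](C)CC[C@]12C` gives 18100 nM as its number. Compound 1 `CC1=CCC[C@H]2[C@](C)(CC3=CC(=O)C(N4CCC[C@H]4C(=O)O)=CC3=O)[C@@H](C)CC[C@]12C` gives 36200 nM in the same read-out, within the scatter of compound 2. Compound 3 `CSCC[C@H](NC1=CC(=O)C=C(C[C@]2(C)[C@@H](C)CC[C@]3(C)C(C)=CCC[C@@H]23)C1=O)C(=O)O` is still unmeasured and carries (1-carboxy-3-(methylsulfanyl)propyl)amino in place of hydrogen on a double-bonded ring carbon, with (1-carboxy-3-(methylsulfanyl)propyl)amino in place of hydrogen on a double-bonded ring carbon as the counted change from compound 2. Among the measured compounds shown here, the one measured step that bears on this change runs the other way, hydrogen in place of 2-carboxypyrrolidin-1-yl on a double-bonded ring carbon, and it shows a 2.0-fold lower number from compound 1 to compound 2 (0.30 log units; within the scatter) as its size. For the measured compounds named here, the entering group differs from the one in compound 1, so this guide is only approximate. In this assay the expected step is a 1.7-fold higher number from compound 2 to compound 3 (0.22 log units; within the scatter) and no shift beyond the scatter is expected. The estimate for compound 3 is 30000 nM with an expected range from 13000 nM to 70000 nM in this read-out.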

Compound 3, half-maximal inhibitory concentration: 13900 nM
Compound 3: the middle estimate sits 2.2-fold (0.33 log units) above what was measured; the range from low to high includes it.
By their numbers in this assay, from the lowest: compounds 3, 2 and 1 (each within the scatter of the next, the first and the last beyond it).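

In this assay the step on the double-bonded ring carbon two ring bonds from the ring atom that bears a large group is small (a 1.3-fold lower number from compound 2 to compound 3 (0.11 log units; within the scatter)), and it stays within the scatter even though a group of 9 heavy atoms replaces hydrogen. Among the compounds shown here, until now the only entering group on a double-bonded ring carbon was 2-carboxypyrrolidin-1-yl, which holds a ring; compound 3 shows the same outcome for (1-carboxy-3-(methylsulfanyl)propyl)amino, which holds none. Nothing measured bears on the reason for this result.

Open, as far as these compounds go, is whether a plain amine without the carboxylic acid, or a longer chain in place of the methylsulfanyl end, would also stay within the scatter of compound 2. The carboxylic acid and the methylsulfanyl group enter together in compound 3, so their separate contributions remain unresolved.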